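Shifting the amino group around the pendant phenyl ring

A few compounds are considered here, and "the series" means these few. Any claim that something is new, unique, unknown or untested is made for them only; others in the source may bear on it.

compound 1 `COC(=O)c1sc2cc(-c3ccoc3)cnc2c1N` — > 120000 nM
compound 2 `COC(=O)c1sc2cc(-c3cccc(N)c3)cnc2c1N` — > 150000 nM

In a functional assay on A-375 cells (Homo sapiens) for inhibition, read by sulforhodamine B assay, with a stated time of 48 h (a lower number here means a stronger inhibitor of growth, a higher number a weaker inhibitor of growth), compound 1 gives > 120000 nM, which is a limit of the assay. Compound 2 gives > 150000 nM, again a limit. The step that the two limits leave unreadable from compound 1 to compound 2 therefore cannot be read. Compound 2 thus stands at a limit, as shown by the limit of > 150000 nM in this assay, at which 1 of the 2 values shown sits, with no number beneath it. Compound 3 `COC(=O)c1sc2cc(-c3ccc(N)cc3)cnc2c1N` differs from compound 2 by 4-aminophenyl in place of 3-aminophenyl on an aromatic carbon. Within the data shown here, no measured step speaks to this change, and the one step known is unreadable. Compound 3 is expected to show a number no higher from compound 2 to compound 3 (the limit leaves the size open), nothing beyond the scatter. The estimate for compound 3 is 150000 nM, between 40000 nM and 600000 nM.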

Compound 3, concentration for 50% growth inhibition: 80800 nM
The estimate for compound 3 lay 1.9-fold (0.27 log units) above the measured number; the range from low to high includes it.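

Setting the amino group as 4-aminophenyl gives the first value in this assay that is a number and not a limit: compound 3 gives 80800 nM. The change of position shows an at least 1.8-fold lower number from compound 2 to compound 3 (0.26 log units; that floor lies within the scatter), and 4-aminophenyl in place of furan-3-yl shows an at least 1.4-fold lower number from compound 1 to compound 3 (0.17 log units; that floor lies within the scatter). The full size of the positional step stays unread because compound 2 stands at a limit: the limit of > 150000 nM in this assay, at which 1 of the 3 values shown sits.

On these data alone, whether a hydroxyl, a methoxy group or a carboxylic acid in place of the amino group on the phenyl ring would also give a number stays open.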